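This account rests on a few compounds, and the source may have more. Where it says the series, first, only, none or still open, it means among the compounds named here.

Measured in a functional assay on HepG2 cells (Homo sapiens) for antiproliferative activity, read by MTT assay, with a stated time of 24 h; on this read-out lower numbers stand for stronger inhibition and higher numbers for weaker inhibition:
- compound 1 `C=CCOc1ccc2c(=O)c(-c3cc(OC)c(OC)cc3OC)coc2c1`: 3450 nM
- compound 2 `COc1cc(OC)c(-c2coc3cc(OCc4ccccc4F)ccc3c2=O)cc1OC`: 1280 nM
- compound 3 `COc1cc(OC)c(-c2coc3cc(OCc4ccccc4C(F)(F)F)ccc3c2=O)cc1OC`: 6550 nM

Compound 3 stands at the high end of these numbers. It is within the scatter of compound 1 (a 1.9-fold higher number from compound 1 to compound 3 (0.28 log units; within the scatter)) but clearly apart from compound 2 (a 5.1-fold higher number from compound 2 to compound 3 (0.71 log units; beyond the scatter)).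

The next change leads to compound 4 `COc1cc(OC)c(-c2coc3cc(OCc4ccc(C#N)cc4)ccc3c2=O)cc1OC`: 4-cyanophenyl in place of 2-(trifluoromethyl)phenyl on a saturated chain carbon bound to an oxygen on an aromatic ring. This puts 4-cyanophenyl in place of 2-(trifluoromethyl)phenyl on a saturated chain carbon bound to an oxygen on an aromatic ring.

Within the data shown here, no measured compound carries a nitrile. The nearest evidence is a 5.1-fold higher number from compound 2 to compound 3 (0.71 log units; beyond the scatter), with a 2.7-fold lower number from compound 1 to compound 2 (0.43 log units; beyond the scatter) as a second guide to how far changes at this place move the number. A modest step to a lower number is therefore expected in this assay. The expected step is a 2.2-fold lower number from compound 3 to compound 4 (0.34 log units; beyond the scatter). For compound 4 the estimated value is 3000 nM, with an expected range of 1000 nM to 9000 nM.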

Compound 4, half-maximal inhibitory concentration: 4230 nM
Compound 4: middle estimate off by 1.4-fold (0.15 log units), on the low side; low and high end bracket the measured number.
By their numbers in this assay, from the lowest: compound 2; then compounds 1, 4 and 3 (each within the scatter of the next).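

Swapping 2-(trifluoromethyl)phenyl for 4-cyanophenyl gives a 1.5-fold lower number from compound 3 to compound 4 (0.19 log units; within the scatter) and so does not separate the two groups, and the comparison with the allyl compound, a 1.2-fold higher number from compound 1 to compound 4 (0.09 log units; within the scatter), also stays unresolved. Compound 2 remains apart from the nitrile compound, with a 3.3-fold higher number from compound 2 to compound 4 (0.52 log units; beyond the scatter), so the nitrile-bearing group joins compounds 1 and 3 rather than compound 2. Nothing available gives a reason for this pattern.

Still open, on these data alone, is whether 2-fluorophenyl holds its place against plain phenyl or 4-fluorophenyl on this chain carbon. As far as these compounds go, how a phenyl group carrying an amine or a carboxylic acid would compare also remains open.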